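The compounds below may be only part of what the source reports. "The series", "measured", "known", "first", "only" and "open" are said of these compounds alone.

Compound 1, `CCN(CC)c1nc(C)nc2c(-c3ccc(OC)c(C)c3C)c(C)nn12`, gives 38.6 nM in an assay on cell membranes for displacement of a labelled ligand from corticotropin-releasing factor receptor 1 (Rattus norvegicus); on this read-out lower numbers stand for stronger inhibition and higher numbers for weaker inhibition.
Compound 2, `CCC(CC)Nc1nc(C)nc2c(-c3cc(F)c(OC)cc3Cl)c(C)nn12`, gives 1 nM in this assay.
Compound 3, `CCC1CCCCN1c1nc(C)nc2c(-c3c(C)cc(OC)cc3OC)c(C)nn12`, gives 3.26 nM in this assay.

Compound 3 stands second highest of the three numbers: compound 2 gives a lower number and compound 1 a higher one, and both gaps lie beyond the scatter. Compound 4, `COc1cc(C)c(-c2c(C)nn3c(NC4CCC4)nc(C)nc23)c(OC)c1`, differs from compound 3 by cyclobutylamino in place of 2-ethylpiperidin-1-yl on an aromatic carbon. Among the measured compounds shown here, no measured pair shows this kind of step directly. The aryl group of compound 3 is kept, and an amino group bearing a hydrogen enters, as in compound 2 with 1 nM, so a modest move toward a lower number, or none beyond the scatter, is expected. The expected step of a 1.3-fold lower number from compound 3 to compound 4 (0.12 log units; within the scatter) is accordingly small. Compound 4 is estimated at 2.5 nM in this assay, within 0.8 nM to 8 nM.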

Compound 4, half-maximal inhibitory concentration: 17.4 nM
Compound 4: the middle estimate sits 7.0-fold (0.84 log units) below what was measured; the measured number lies above the stated range.
By their numbers in this assay, from the lowest: compound 2; then compound 3; then compound 4; then compound 1.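

In this assay, the exchange of 2-ethylpiperidin-1-yl for cyclobutylamino, on an aromatic carbon between two ring nitrogen atoms and with the aryl group kept, gives a 5.3-fold higher number from compound 3 to compound 4 (0.73 log units; beyond the scatter). This first direct step at the position shows that the substituent there matters, and that an amino group bearing a hydrogen does not by itself secure a low number. Nothing available accounts for the rise. Still open, from the compounds shown here alone, is whether cyclopentylamino or pyrrolidin-1-yl on the same aryl group would separate the effect of ring size from that of the amino hydrogen. Going by these compounds, whether the step carries over to other aryl groups also remains open.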